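Amide Variation and Clearance Notes on a Small Series

The compounds below may be only part of what the source reports. "The series", "measured", "known", "first", "only" and "open" are said of these compounds alone.

Measured so far:
compound 1, `O=C(CCNc1nc2cc(Cl)ccc2o1)N1CCCC1`, 2.3 mL/min/g
compound 2, `O=C(CCSc1nc2cc(Cl)ccc2o1)NC1CCCC1`, 11.3 mL/min/g

In an ADME assay on microsomes from liver (Homo sapiens) for metabolic stability, read by LC-MS, using NADPH, with a stated time of 45 min, tested at 0.5 uM (on this read-out higher numbers stand for fast clearance and lower numbers for slow clearance), compound 2 gives 11.3 mL/min/g, the higher of the two numbers; its nearest neighbour, compound 1, gives 2.3 mL/min/g, and that gap lies beyond the usual scatter. Among the measured compounds shown here, no single-point step between these two has been worked out, so the two values are simply set side by side.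

Compound 3, `O=C(CCSc1nc2cc(Cl)ccc2o1)N1CCCCC1`, has not yet been measured in this assay. It differs from compound 2 by one change: piperidin-1-yl in place of cyclopentylamino on a carbonyl carbon. For the measured compounds named here, no measured pair isolates this kind of change, so there is nothing in the data to size it from. The step of a 1.3-fold lower number from compound 2 to compound 3 (0.10 log units; within the scatter) is expected to stay small, with no clear direction beyond the scatter. Compound 3 is estimated at 9 mL/min/g, within a range from 4 mL/min/g to 20 mL/min/g, in this assay.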

Compound 3, intrinsic clearance in a liver preparation (reported as CLH), per the amount of preparation that the assay uses: 10.7 mL/min/g
Compound 3: middle estimate off by 1.2-fold (0.08 log units), on the low side; measured number inside the range.
By their numbers in this assay, from the lowest: compound 1; then compounds 3 and 2 (each within the scatter of the next).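

In this assay, among the compounds shown here, the exchange of cyclopentylamino for piperidin-1-yl on a carbonyl carbon gives a 1.1-fold lower number from compound 2 to compound 3 (0.02 log units; within the scatter) and so marks the first single-place comparison. At this position, the hydrogen-bond donor count goes from 1 to 0 and the ring changes from a five-membered carbon ring to a six-membered ring with 1 hetero atom, yet compound 2 and compound 3 cannot be told apart in this read-out. The two groups are therefore interchangeable here as far as this one pair shows. No supporting data bear on why this pair shows no separation.

Compound 1 differs from compound 2 and from compound 3 in more than one place, so its value cannot be assigned to any single change. On these data alone, whether a morpholin-4-yl group or a carboxylic acid on this chain would also fall within the scatter remains open.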